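Carbonyl substituent replacement on the piperidine-bearing series

This account rests on a few compounds, and the source may have more. Where it says the series, first, only, none or still open, it means among the compounds named here.

Among the measured compounds shown here, compound 1 `Cc1nc(S(C)(=O)=O)ccc1Oc1ncnc(OC2CCN(C(=O)O[C@H](C)CF)CC2)c1F` gives 196 nM in a functional assay on isolated protein for inhibition of Glucose-dependent insulinotropic receptor (Homo sapiens), read by HTRF and cAMP accumulation (on this read-out higher numbers stand for an effect only at larger amounts of compound and lower numbers for an effect already at smaller amounts), the highest of the three numbers measured so far. Compound 2 `Cc1nc(S(C)(=O)=O)ccc1Oc1ncnc(OC2CCN(C(=O)O[C@@H](C)CF)CC2)c1F` gives 186 nM; the pair shows a 1.1-fold lower number from compound 1 to compound 2 (0.02 log units; within the scatter), consistent with the fact that compounds 1 and 2 differ only in the configuration as drawn. Compound 3 `Cc1nc(S(C)(=O)=O)ccc1Oc1ncnc(OC2CCN(C(=O)SC3(C)CC3)CC2)c1F` gives 13.2 nM, and the step of a 15-fold lower number from compound 1 to compound 3 (1.17 log units; beyond the scatter) is the one large movement in the set; the same change from compound 2 reads a 14-fold lower number from compound 2 to compound 3 (1.15 log units; beyond the scatter).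

Compound 4 `Cc1nc(S(C)(=O)=O)ccc1Oc1ncnc(OC2CCN(C(=O)C3(F)CCC3)CC2)c1F` is not yet measured. Against compound 1 the change is a group of 5 heavy atoms (4 carbon, 1 fluorine; one four-membered non-aromatic ring of carbon only) in place of a group of 5 heavy atoms (3 carbon, 1 oxygen, 1 fluorine; no ring), on a carbonyl carbon. For the measured compounds named here, the only measured step bearing on this position is the exchange from compound 1 to compound 3, where a ring-bearing group of the same heavy-atom count on the carbonyl carbon gave a 15-fold lower number from compound 1 to compound 3 (1.17 log units; beyond the scatter). Compound 4 likewise places a small carbocyclic ring on the carbonyl carbon, so a lower number in this assay is expected, though the new group differs in kind from that of compound 3 and the size of the gain is uncertain. For compound 4 the estimate is 40 nM, range 10 nM to 150 nM. This expected step is a 4.9-fold lower number from compound 1 to compound 4 (0.69 log units; beyond the scatter).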

Compound 4, half-maximal effective concentration: 24.7 nM
Estimate against measurement, compound 4: 1.6-fold (0.21 log units) above, within the range that was stated.
By their numbers in this assay, from the lowest: compounds 3 and 4 (each within the scatter of the next); then compounds 2 and 1 (each within the scatter of the next).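

Sulfur is not required for the gain on this carbonyl carbon: the group with a four-membered non-aromatic ring of carbon only, which keeps a fluorine and has no sulfur, gives a 7.9-fold lower number from compound 1 to compound 4 (0.90 log units; beyond the scatter) and a 7.5-fold lower number from compound 2 to compound 4 (0.88 log units; beyond the scatter). Set against the other ring-bearing group, it gives a 1.9-fold higher number from compound 3 to compound 4 (0.27 log units; within the scatter), so a three-membered ring is not required either, and the two ring-bearing groups cannot be told apart in this assay. Nothing measured here gives a cause for the gain from either ring-bearing group.

Open, going by these compounds, is whether the fluorine on the four-membered ring matters, which a plain cyclobutyl group on the same carbonyl carbon would test. Also open, on these data alone, is whether any ring is needed at all, which a tert-butyl group or a dimethylamino group there would test.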